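This account rests on a few compounds, and the source may have more. Where it says the series, first, only, none or still open, it means among the compounds named here.

Measured compounds:
- compound 1, `CCNC(=O)OC(C)(C)CCCC(C)C/C=C/C(C)=C/C(=O)OCC`: 5.65
- compound 2, `CCNC(=O)OC(C)(C)CCCC(C)C/C=C/C(C)=C/C(=O)OC(C)C`: 6.06
- compound 3, `CCNC(=O)/C=C(C)/C=C/CC(C)CCCC(C)C`: 5.24

The series is followed in a physicochemical assay for lipophilicity; a lower number here means a more polar compound, a higher number a more lipophilic compound. Compound 1 carries an ethoxycarbonyl group; compound 2 replaces it by isopropoxycarbonyl. The change is methyl in place of hydrogen on a saturated chain carbon bound to an oxygen next to a carbonyl group and a saturated chain carbon and gives a number 0.41 log units higher from compound 1 to compound 2 (beyond the scatter).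

Compound 3 holds the lowest value of the three; the difference between its core and that of compound 1 is not broken down here.

Compound 4, `CC(/C=C/CC(C)CCCC(C)C)=C\C(=O)NC(C)C`, is the unmeasured partner of compound 3. The change is methyl in place of hydrogen on a saturated chain carbon bound to an amide-type nitrogen and a saturated chain carbon. This is the same kind of change as from compound 1 to compound 2, but the place differs: there the carbon is bound to an oxygen next to a carbonyl group, here to an amide-type nitrogen.

Because compound 1 to compound 2 gave a number 0.41 log units higher from compound 1 to compound 2 (beyond the scatter), compound 3 to compound 4 is expected to give a number 0.41 log units higher from compound 3 to compound 4 (beyond the scatter) in this assay.

Compound 4 is therefore estimated at 5.65, with a range of 5.3 to 6.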

Compound 4, partition coefficient: 5.65
The estimate for compound 4 equals the measured number at the digits printed, within the range that was stated.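

In this assay, methyl in place of hydrogen gives a number 0.41 log units higher from compound 3 to compound 4 (beyond the scatter), the same size as a number 0.41 log units higher from compound 1 to compound 2 (beyond the scatter), so the change carried over from the core of compound 1 to the core of compound 3 with its step intact. This rests on a single pair on each core, so it shows agreement for these compounds only and gives no rule for other places or other cores in the series. Nothing available here bears on what lies behind the step.

The compounds shown leave open whether the step continues from isopropyl to tert-butyl or to a longer chain. Also open, going by these compounds, is how a carboxylic acid or an amine in place of the ethylcarbamoyl group would read in this assay.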